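Replacing a Methylcyclohexyl Amide with a Dimethylmorpholine Urea

A few compounds are considered here, and "the series" means these few. Any claim that something is new, unique, unknown or untested is made for them only; others in the source may bear on it.

Of the compounds shown here, two have been measured in an assay on HEK293 cells for positive allosteric modulation of metabotropic glutamate receptor 5 (Homo sapiens), read by FLIPR; a higher number here means that more compound is needed for the effect, a lower number that less compound is needed. Compound 1 `Cc1cccc(-c2noc(C3CN(S(=O)(=O)c4cccc(C)c4)C3)n2)c1` gives only a limit in this assay, > 10000 nM, and this limit is not a number; it is the one noted at the limit of > 10000 nM in this assay, at which 1 of the 2 values shown sits. Within the data shown here, compound 2 `CC1CCCC(C(=O)N2CC(c3nc(-c4cccc(Cl)c4)no3)C2)C1` gives 410 nM in this assay, which is the only number among the two values shown. Among the measured compounds shown here, no pair of measured compounds differs in a single place, so no measured step between them is available.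

Compound 3 `CC1CN(C(=O)N2CC(c3nc(-c4cccc(Cl)c4)no3)C2)CC(C)O1` has not yet been measured in this assay. It differs from compound 2 in one place: 2,6-dimethylmorpholin-4-yl in place of 3-methylcyclohexyl on a carbonyl carbon. The change sets 2,6-dimethylmorpholin-4-yl in place of 3-methylcyclohexyl on a carbonyl carbon, whose other neighbour is an amide-type nitrogen in a ring.

Without a measured step to rest on, the expected step from compound 2 to compound 3 is a 2.4-fold higher number from compound 2 to compound 3 (0.39 log units; beyond the scatter), a modest weakening that may still lie close to the scatter of the assay. For compound 3 the estimated value in this assay is 1000 nM, with a range from 300 nM to 4000 nM.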

Compound 3, half-maximal effective concentration: > 10000 nM
Compound 3: only a limit was reported; the forecaster's own chance of this, stated with the estimate: 15%; at least 10-fold (1.00 log units) between middle value and limit.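

Among these compounds, this is the first measured step at this place, and it shows that the carbonyl carbon, whose other neighbour is an amide-type nitrogen in a ring, does not accept every six-membered ring: in this assay, 2,6-dimethylmorpholin-4-yl in place of 3-methylcyclohexyl gives an at least 24-fold higher number from compound 2 to compound 3 (1.38 log units; beyond the scatter) and so takes the series from a measurable value to the top of the assay's range. Compound 3 gives > 10000 nM, which is a limit and not a number. The step therefore marks only the smallest possible change, and its full size cannot be read because compound 3 sits at that limit, as compound 1 also does: (the limit of > 10000 nM in this assay, at which 2 of the 3 values shown sit).

The compounds shown leave open whether the loss goes with the ring oxygen, with the ring nitrogen now bound to the carbonyl carbon, or with the two methyl groups, since all of these enter in the one step. An unsubstituted morpholin-4-yl or a plain piperidin-1-yl at this place would begin to separate these features, and the limit leaves open how far compound 3 lies from compound 2.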